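The compounds below may be only part of what the source reports. "The series", "measured", "known", "first", "only" and "open" are said of these compounds alone.

Measured in a functional assay on ECa-109 cells (Homo sapiens) for antiproliferative activity, with a stated time of 72 h; on this read-out lower numbers stand for stronger inhibition and higher numbers for weaker inhibition:
- compound 1 `COc1cc(OC)c(C(=O)/C=C/c2ccccc2Cl)c(O)c1CN1CCCC1`: 6900 nM
- compound 2 `CCN(C)Cc1c(OC)cc(OC)c(C(=O)/C=C/c2ccccc2Cl)c1O`: 1400 nM
- compound 3 `CCN(CC)Cc1c(OC)cc(OC)c(C(=O)/C=C/c2ccccc2Cl)c1O`: 7100 nM

Compound 3 stands at the weak end of this small series, a place it shares with one other member: the data show a 1.0-fold higher number from compound 1 to compound 3 (0.01 log units; within the scatter). The remaining member is set apart by a 5.1-fold higher number from compound 2 to compound 3 (0.71 log units; beyond the scatter), and also by a 4.9-fold lower number from compound 1 to compound 2 (0.69 log units; beyond the scatter).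

Compound 4 `COc1cc(OC)c(C(=O)/C=C/c2ccccc2Cl)c(O)c1CN(C)CCCN(C)C` has a new amine on the saturated chain carbon bound to an aromatic carbon: (3-(dimethylamino)propyl)(methyl)amino in place of diethylamino on a saturated chain carbon bound to an aromatic carbon. Among the compounds with values here, no measured step covers an amine of this kind. Within the data shown here, compound 2, at 1400 nM, shows only that a change of amine can lower the number by a modest step, so a modest step in that direction is expected, with wide uncertainty. The expected change is a 2.2-fold lower number from compound 3 to compound 4 (0.35 log units; beyond the scatter). For compound 4 the estimated value is 3200 nM, with an expected range of 1000 nM to 10000 nM.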

Compound 4, half-maximal inhibitory concentration: 3800 nM
For compound 4 the middle estimate is 1.2-fold (0.07 log units) below the measured one; low and high end bracket the measured number.
By their numbers in this assay, from the lowest: compound 2; then compounds 4, 1 and 3 (each within the scatter of the next).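

In this assay, the larger (3-(dimethylamino)propyl)(methyl)amino on the saturated chain carbon bound to an aromatic carbon cannot be told apart from the smaller amines diethylamino and pyrrolidin-1-yl, as both a 1.9-fold lower number from compound 3 to compound 4 (0.27 log units; within the scatter) and a 1.8-fold lower number from compound 1 to compound 4 (0.26 log units; within the scatter) show. Within the data shown here, the only step here beyond the scatter is the modest one to the ethyl(methyl)amino compound (a 2.7-fold higher number from compound 2 to compound 4 (0.43 log units; beyond the scatter)), so the added chain and second nitrogen do not match that amine. No evidence is available to explain these results.

Still open, from the compounds shown here alone, is whether dimethylamino or morpholine at this position would fall with compound 2 or with the rest. Also open, going by these compounds, is how a shorter ethylene chain between the two nitrogens would compare.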